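Swapping a Pyrazole for a Fluorophenyl on a Shared Core

The source may report more compounds than this note shows. Statements on the series, on what has been measured and on what is new or still open speak of the compounds shown alone.

Two compounds with the same core frame this comparison. In a functional assay on CCRF-CEM cells (Homo sapiens) for inhibition (a lower number here means a stronger inhibitor, a higher number a weaker inhibitor), compound 1 `Cc1csc(-c2ncnc3c2ncn3C2O[C@H](CO)[C@@H](O)[C@H]2O)n1` gives 6000 nM, while compound 2 `Cn1nccc1-c1ncnc2c1ncn2C1O[C@H](CO)[C@@H](O)[C@H]1O` is recorded as "not active" (no number reported). Compound 2 therefore has no single number, and the size of its gap to compound 1 cannot be stated. It stands only as a compound for which no measurable inhibition was reported.

Compound 3 `OC[C@H]1OC(n2cnc3c(-c4ccc(F)cc4)ncnc32)[C@H](O)[C@@H]1O` has not yet been measured. The structural change is 4-fluorophenyl in place of 1-methyl-1H-pyrazol-5-yl on an aromatic carbon. The exchange takes place on an aromatic carbon of a six-membered aromatic ring with 2 nitrogen, part of a fused or bridged system of two rings.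

For the measured compounds named here, with no measured step to draw on, the expectation is tentative. A move towards stronger inhibition in this assay is expected, from no number to a measurable one, though a second result without a number remains possible. Going by the values given here, the only numerical guide is compound 1 at 6000 nM, so a value at a similar level is anticipated. Compound 3 is expected at about 5000 nM, with an estimated range of 1000 nM to 25000 nM.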

Compound 3, half-maximal inhibitory concentration: 700 nM
For compound 3 the middle estimate is 7.1-fold (0.85 log units) above the measured one, outside the stated range (below it).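

At this aromatic carbon of the shared core, the first measurable comparison comes from placing 4-fluorophenyl in place of 4-methyl-1,3-thiazol-2-yl, which gives an 8.6-fold lower number from compound 1 to compound 3 (0.93 log units; beyond the scatter) in this assay. The position is therefore not indifferent to the group it carries: the step is modest but lies beyond the scatter, and it shows that a carbon-only aromatic ring here is compatible with stronger inhibition than the thiazole of compound 1 gives. The change from 1-methyl-1H-pyrazol-5-yl cannot be read as a step, since compound 2 has no number, and the data offer no measured property that would explain the difference between these groups.

What the compounds shown leave open is whether the fluorine matters at all, or whether a plain phenyl, or a phenyl carrying a methoxy group or an amine, would stand level with compound 3 in this assay. They also leave open whether this level would hold if one of the hydroxyl groups on the shared core were replaced by a fluorine or a methoxy group.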